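Hydrazide Replaced by Phenylpiperazine Amide on a Shared Core

This account rests on a few compounds, and the source may have more. Where it says the series, first, only, none or still open, it means among the compounds named here.

Compound 1 `CN1CCN(C(=O)c2c(NC(=O)NS(=O)(=O)c3ccccc3)sc3c2CCCCC3)CC1` gives 42300 nM in a functional assay on cells (Cancer cell lines, Homo sapiens) for inhibition, with a stated time of 48 h; a lower number here means a stronger inhibitor of growth, a higher number a weaker inhibitor of growth.
Compound 2 `CCCCNC(=O)c1c(NC(=O)NS(=O)(=O)c2ccccc2)sc2c1CCCCC2` gives 72300 nM in this assay.
Compound 3 `O=C(Nc1sc2c(c1C(=O)NNc1ccc(Cl)cc1)CCCCC2)NS(=O)(=O)c1ccccc1` reaches only a limit in this assay, namely > 100000 nM.

For the measured compounds named here, compound 3 therefore stands at the edge of what the measurement can report: its entry is a limit, not a number, and it is the one member of the set sitting there (the limit of > 100000 nM in this assay, at which 1 of the 3 values shown sits). Compound 4 `O=C(Nc1sc2c(c1C(=O)N1CCN(c3ccccc3)CC1)CCCCC2)NS(=O)(=O)c1ccccc1` differs from compound 3 at a single position: 4-phenylpiperazin-1-yl in place of ((4-chlorophenyl)amino)amino on a carbonyl carbon.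

Of the measured steps, the one that speaks most directly to this change is the move into compound 3 from an amide built on a piperazine, an at least 2.3-fold higher number from compound 1 to compound 3 (0.37 log units; beyond the scatter). The remaining steps, a 1.7-fold higher number from compound 1 to compound 2 (0.23 log units; within the scatter) and an at least 1.3-fold higher number from compound 2 to compound 3 (0.14 log units; that floor lies within the scatter), stayed within the scatter. Walking back from the hydrazide toward a piperazine amide is thus expected to lower the number, by a modest amount, though with three compounds the pattern rests on thin ground.

In this assay compound 4 is expected near 60000 nM, within a range from 25000 nM to 150000 nM. The expected change amounts to an at least 1.6-fold lower number from compound 3 to compound 4 (0.22 log units; that floor lies within the scatter).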

Compound 4, concentration for 50% growth inhibition: 65200 nM
Compound 4: the middle estimate sits 1.1-fold (0.04 log units) below what was measured, within the range that was stated.
By their numbers in this assay, from the lowest: compounds 1, 4 and 2 (each within the scatter of the next). At a limit, above all of these: compound 3.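

In this assay the 4-phenylpiperazin-1-yl group on the carbonyl carbon gives a value that reads as a number, and the exchange yields an at least 1.5-fold lower number from compound 3 to compound 4 (0.18 log units; that floor lies within the scatter) so only a floor on this step is known, and that floor does not by itself separate the two groups. A phenyl in place of methyl on the ring amine nitrogen gives a 1.5-fold higher number from compound 1 to compound 4 (0.19 log units; within the scatter) and the exchange for butylamino gives a 1.1-fold lower number from compound 2 to compound 4 (0.04 log units; within the scatter) so compounds 1, 2 and 4 do not part from one another in this assay, even with an added aromatic ring on the piperazine. Compound 3 alone stays at a limit of the assay: the limit of > 100000 nM in this assay, at which 1 of the 4 values shown sits.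

The compounds shown leave open whether the hydrazide link itself or its 4-chlorophenyl ring sets compound 3 apart. They also leave open whether a morpholine amide, or a piperazine carrying a carboxylic acid chain on its ring nitrogen, would move the number on this carbonyl carbon beyond the scatter from compounds 1, 2 and 4.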